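Chloro to methyl on the benzyl group

This account rests on a few compounds, and the source may have more. Where it says the series, first, only, none or still open, it means among the compounds named here.

Measured compounds:
compound 1 `N#C/C(=C\c1ccccc1OS(=O)(=O)c1ccc([N+](=O)[O-])cc1)C(=O)Nc1nnc(Cc2ccccc2)s1` gives 20%
compound 2 `N#C/C(=C\c1ccccc1OS(=O)(=O)c1ccc([N+](=O)[O-])cc1)C(=O)Nc1nnc(Cc2ccc(Cl)cc2)s1` gives 34%

In a functional assay on HL-60 cells (Homo sapiens) for inhibition, read by CCK-8 assay, with a stated time of 48 h, tested at 20 uM (a higher number here means more inhibition of growth at the concentration tested, a lower number less inhibition of growth), compound 2 stands highest of the two measured compounds. Compound 3 `Cc1ccc(Cc2nnc(NC(=O)/C(C#N)=C/c3ccccc3OS(=O)(=O)c3ccc([N+](=O)[O-])cc3)s2)cc1` carries methyl in place of chloro on an aromatic carbon. Going by the values given here, one measured step bears on this change, chloro in place of hydrogen on that same carbon (a number 14 percentage points higher from compound 1 to compound 2 (beyond the scatter)). Among the compounds with values here, no measured compound carries methyl, so this step guides the expectation only loosely. A small drop, possibly none beyond the scatter, is expected in this assay (a number 5 percentage points lower from compound 2 to compound 3 (within the scatter)). Compound 3 is estimated at 29% (range 16% to 42%).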

Compound 3, percent growth inhibition at one concentration: 17%
Beside the measured number, compound 3's estimate is 12 percentage points above it, and the stated range covers the measured number.
By their numbers in this assay, from the lowest: compounds 3 and 1 (each within the scatter of the next); then compound 2.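

In this assay there is a number 17 percentage points lower from compound 2 to compound 3 (beyond the scatter) and a number 3 percentage points lower from compound 1 to compound 3 (within the scatter) when methyl takes this place on the benzyl group. The gain seen with chloro on this carbon therefore does not carry over to methyl, and among hydrogen, chloro and methyl only chloro stands apart here. Nothing measured here explains why chloro and methyl differ at this carbon.

On these data alone, whether fluoro, methoxy or an amine on this carbon would match chloro or methyl stays open. So does whether chloro would give a similar step at another carbon of this six-membered ring.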